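The compounds below may be only part of what the source reports. "The series", "measured", "known", "first", "only" and "open" are said of these compounds alone.

Compound 1 `CC(C)(O)C#Cc1cc(C(O)(C(F)(F)F)C(F)(F)F)cnc1N1CCN(S(=O)(=O)c2ccc(N)nc2)CC1`: 16 mL.min-1.g-1
Compound 2 `Nc1ccc(S(=O)(=O)N2CCN(c3ncc(C(O)(C(F)(F)F)C(F)(F)F)cc3-c3cnccc3F)CC2)cn1`: 22 mL.min-1.g-1
Compound 3 `Nc1ccc(S(=O)(=O)N2CCN(c3ncc(C(O)(C(F)(F)F)C(F)(F)F)cc3-c3ccc4ocnc4c3)CC2)cn1`: 120 mL.min-1.g-1

All three values come from an ADME assay (liver) for metabolic stability, with Liver microsome (Rattus norvegicus) as the target, using microsomes and NADPH, with a stated time of 30 min, tested at 1 uM; a lower number here means slower removal, a higher number faster removal of the compound. Compound 3 has the highest number of the set, and both steps up to it lie beyond the usual scatter: a 7.5-fold higher number from compound 1 to compound 3 (0.88 log units; beyond the scatter) and a 5.5-fold higher number from compound 2 to compound 3 (0.74 log units; beyond the scatter). By contrast, a 1.4-fold higher number from compound 1 to compound 2 (0.14 log units; within the scatter) lies within the scatter.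

Compound 4 `Nc1ccc(S(=O)(=O)N2CCN(c3ncc(C(O)(C(F)(F)F)C(F)(F)F)cc3-c3cccc4[nH]ncc34)CC2)cn1` keeps the core of compound 3 and changes one group: 1H-indazol-4-yl in place of 1,3-benzoxazol-5-yl on an aromatic carbon. All three measured steps concern this same aromatic carbon, so they show that a change here can move the number. None of them involves 1H-indazol-4-yl, however, so the evidence is indirect. Both other groups measured here give lower numbers than the 1,3-benzoxazol-5-yl group of compound 3, which stands at 120 mL.min-1.g-1. A modest fall is therefore expected, smaller than the measured rises to compound 3.

The expected change is a 2.2-fold lower number from compound 3 to compound 4 (0.34 log units; beyond the scatter). For compound 4 the estimated value is 55 mL.min-1.g-1, with an expected range from 20 mL.min-1.g-1 to 130 mL.min-1.g-1.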

Compound 4, intrinsic clearance in microsomes: 93 mL.min-1.g-1
Estimate against measurement, compound 4: 1.7-fold (0.23 log units) below; low and high end bracket the measured number.
By their numbers in this assay, from the lowest: compounds 1 and 2 (each within the scatter of the next); then compounds 4 and 3 (each within the scatter of the next).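

Replacing 1,3-benzoxazol-5-yl with 1H-indazol-4-yl has little effect in this assay (a 1.3-fold lower number from compound 3 to compound 4 (0.11 log units; within the scatter)), even though the entering group carries a hydrogen-bond donor and the leaving group carries none. The higher clearance is therefore not confined to compound 3, since compound 4 also stands clearly apart from the other two compounds (a 4.2-fold higher number from compound 2 to compound 4 (0.63 log units; beyond the scatter); a 5.8-fold higher number from compound 1 to compound 4 (0.76 log units; beyond the scatter)). Nothing available explains what compounds 3 and 4 share in this respect.

The compounds shown leave open whether having a five-membered aromatic ring joined to a six-membered one is what matters, or whether a plain phenyl ring would give a similarly high number. They also leave open how the number would respond to 1-methyl-1H-indazol-4-yl, in which a methyl group replaces the ring hydrogen-bond donor.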